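Chloro in Place of Methyl across Two Cores

The compounds below may be only part of what the source reports. "The series", "measured", "known", "first", "only" and "open" are said of these compounds alone.

The measured compounds:
compound 1 `C[C@@H]1CCC[C@H](C)N1CCCNC(=O)c1cc(Cl)ccc1O`, 30 ug/mL
compound 2 `Cc1ccc(O)c(C(=O)NCCCN2[C@H](C)CCC[C@@H]2C)c1`, a limit of the assay, > 100 ug/mL
compound 3 `Cc1ccc(O)c(C(=O)NCCCN2CCC[C@@H]3CCCC[C@H]32)c1`, 60 ug/mL

In a functional assay on MDBK cells (Bos taurus) for cytotoxicity (on this read-out higher numbers stand for lower toxicity in this test and lower numbers for higher toxicity in this test), compound 1 gives 30 ug/mL. For compound 2 the assay reports only a limit, > 100 ug/mL; this is the limit of > 100 ug/mL in this assay, at which 1 of the 3 values shown sits. The change between them is chloro in place of methyl on an aromatic carbon, and it made an at least 3.3-fold lower number from compound 2 to compound 1 (0.52 log units; beyond the scatter). Compound 3 carries a different core; the difference between the two cores is not broken down here. In this assay compound 3 gives 60 ug/mL, and beside compound 1 this lies within the scatter.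

Compound 4 `O=C(NCCCN1CCC[C@@H]2CCCC[C@H]21)c1cc(Cl)ccc1O` differs from compound 3 by chloro in place of methyl on an aromatic carbon. The surroundings of the place are the same word for word as in the earlier step, so this is the same change. Compound 4 is expected to follow the earlier step, an at least 3.3-fold lower number from compound 2 to compound 1 (0.52 log units; beyond the scatter), with a step of about a 3.0-fold lower number from compound 3 to compound 4 (0.48 log units; beyond the scatter). Compound 4 is estimated at 20 ug/mL, within 8 ug/mL and 60 ug/mL.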

Compound 4, half-maximal cytotoxic concentration: 45 ug/mL
Compound 4: the middle estimate sits 2.3-fold (0.35 log units) below what was measured; the measured number falls inside the stated range.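

In this assay, chloro in place of methyl on an aromatic carbon gave a 1.3-fold lower number from compound 3 to compound 4 (0.12 log units; within the scatter). Set beside the earlier step, the change reads as follows on the two cores: the same change on two cores in this assay, an at least 3.3-fold lower number (0.52 log units; beyond the scatter) from compound 2 to compound 1 and a 1.3-fold lower number (0.12 log units; within the scatter) from compound 3 to compound 4; the limit leaves it open whether they differ. The change therefore does not give a step beyond the scatter on both cores, but these pairs do not show that the core alters its effect, since the value of compound 2 is only a limit of the assay and not a number: the limit of > 100 ug/mL in this assay, at which 1 of the 4 values shown sits.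

The compounds shown leave open how the same change would read on a third core, or on either core with a longer chain in the linker between the amide and the ring nitrogen. They also leave open whether a fluoro, a bromo or a methoxy group in place of the chloro would follow compound 1 and compound 4 in this test of toxicity, as only chloro and methyl appear at that place.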